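The source may hold more compounds than are shown below. What is called first, only, known or untested is meant among the compounds shown, and "the series" means these compounds.

Of the compounds shown here, three have so far been measured in a functional assay on HEK293 cells for antagonist activity at 5-hydroxytryptamine receptor 6 (Homo sapiens), read by cAMP accumulation, with stated times of 10 min and 1 h; on this read-out lower numbers stand for stronger inhibition and higher numbers for weaker inhibition. Compound 1 `Cc1c(/C=N/N2CCN(C)CC2)c2ccccc2n1S(=O)(=O)c1ccc(F)cc1` gives 4740 nM, compound 2 `Cc1c(/C=N/N2CCN(C)CC2)c2ccccc2n1S(=O)(=O)c1ccc2ccccc2c1` gives 2040 nM, and compound 3 `CN1CCN(/N=C/c2c(-c3ccccc3)n(S(=O)(=O)c3ccccc3)c3ccccc23)CC1` gives 1800 nM, the lowest of the three numbers, although its gap to compound 2 lies within the scatter and only its gap to compound 1 lies beyond it. Compound 4 `CN1CCN(/N=C/c2c(-c3ccccc3)n(S(=O)(=O)c3cccc4ccccc34)c3ccccc23)CC1` differs from compound 3 by naphthalen-1-yl in place of phenyl on a sulfonyl sulfur. For the measured compounds named here, the one measured step that bears on such an enlargement on the sulfonyl sulfur is a 2.3-fold lower number from compound 1 to compound 2 (0.37 log units; beyond the scatter), a modest change. A lowering of similar size, or none beyond the scatter, is therefore expected in this assay, namely a 1.8-fold lower number from compound 3 to compound 4 (0.26 log units; within the scatter). Compound 4 is accordingly estimated at 1000 nM, with a range from 400 nM to 3000 nM.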

Compound 4, half-maximal inhibitory concentration: 6600 nM
The estimate for compound 4 lay 6.6-fold (0.82 log units) below the measured number, and the stated range ends below it.
By their numbers in this assay, from the lowest: compounds 3 and 2 (each within the scatter of the next); then compounds 1 and 4 (each within the scatter of the next).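

On the sulfonyl sulfur, adding a second aromatic ring does not move this assay in one fixed direction: the step of a 3.7-fold higher number from compound 3 to compound 4 (0.56 log units; beyond the scatter) runs opposite to the step of a 2.3-fold lower number from compound 1 to compound 2 (0.37 log units; beyond the scatter). These two steps start from different cores and bring in different naphthalenyl groups, so neither can be read as a general effect of ring enlargement. No evidence is available to explain the reversal. The compounds shown leave open how naphthalen-2-yl would read on the core of compound 3, and how a pyridin-3-yl ring on the sulfonyl sulfur would compare with phenyl.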